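Working notes: from compound 3 to compound 4

The source may report more compounds than this note shows. Statements on the series, on what has been measured and on what is new or still open speak of the compounds shown alone.

Going by the values given here, in a functional assay on PANC-1 cells (Homo sapiens) for cytotoxicity, read by WST assay, with a stated time of 24 h (on this read-out lower numbers stand for stronger inhibition and higher numbers for weaker inhibition), compound 3 `O=C(CCCCCCCCc1ccccc1F)N1CCCCC1` gives 98900 nM, the only actual number so far. Compound 1 `Cc1ccc(CCCCCCCCC(=O)N2CCCCC2)cc1` reads > 100000 nM, which is a limit of the assay. Compound 2 `O=C(CCCCCCCCc1ccc(O)cc1)N1CCCCC1` reads > 100000 nM, also a limit. The rest of the evidence is the limit of > 100000 nM in this assay, at which 2 of the 3 values shown sit.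

Compound 4 `O=C(CCCCCCCCc1ccc(Cl)cc1)N1CCCCC1` takes the series one step further: 4-chlorophenyl in place of 2-fluorophenyl on a saturated chain carbon, eight bonds along the chain from a carbonyl carbon. Two measured steps change the phenyl group at this same place, on a saturated chain carbon: a number no higher from compound 1 to compound 3 (the limit leaves the size open) and a number no higher from compound 2 to compound 3 (the limit leaves the size open). Neither has a readable size, so they give no measure of how far such a change moves the value. The expectation therefore stays anchored on compound 3 at 98900 nM, with no shift beyond the scatter anticipated. There is also a fair chance that compound 4 reads as another limit. The expected step is a 1.1-fold lower number from compound 3 to compound 4 (0.04 log units; within the scatter). For compound 4 the estimated value in this assay is 90000 nM, with an expected range of 40000 nM to 200000 nM.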

Compound 4, half-maximal inhibitory concentration: 65500 nM
Estimate against measurement, compound 4: 1.4-fold (0.14 log units) above, and the stated range covers the measured number.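

In this assay, going by these compounds alone, compound 4 provides the second actual number, so a change of the phenyl group on this saturated chain carbon can be sized for the first time: a 1.5-fold lower number from compound 3 to compound 4 (0.18 log units; within the scatter). That step lies within the scatter, so this assay does not separate 4-chlorophenyl from 2-fluorophenyl at this place. Against the two limits, the result adds only an at least 1.5-fold lower number from compound 2 to compound 4 (0.18 log units; that floor lies within the scatter) and an at least 1.5-fold lower number from compound 1 to compound 4 (0.18 log units; that floor lies within the scatter), and neither floor lies beyond the scatter.

Going by these compounds, whether any group at this place can move the value beyond the scatter remains open, and much of the series still rests on limits: the limit of > 100000 nM in this assay, at which 2 of the 4 values shown sit. The compounds shown also leave open what an amine or a carboxylic acid in place of the chloro, or a longer chain, would give in this assay.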